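Three Sulfonamides at the Assay Limit, a Fourth Awaited

The source may hold more compounds than are shown below. What is called first, only, known or untested is meant among the compounds shown, and "the series" means these compounds.

Compound 1, `COc1cccc(S(=O)(=O)Nc2ccc3oc(-c4ccccc4)nc3c2)c1`: in an assay on isolated protein for inhibition of malate dehydrogenase, mitochondrial (Sus scrofa), with stated times of 45 min and 30 min (a higher number here means a weaker inhibitor, a lower number a stronger inhibitor), compound 1 gives > 63000 nM, a limit of the assay.
Compound 2, `O=S(=O)(Nc1ccc2oc(-c3ccccc3)nc2c1)c1cccc(Cl)c1`: in this assay compound 2 gives > 63000 nM, a limit of the assay.
Compound 3, `COc1ccc(S(=O)(=O)Nc2ccc3oc(-c4ccccc4)nc3c2)cc1`: in this assay compound 3 gives > 63000 nM, a limit of the assay.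

Compound 3 therefore stands only at a limit, and every value shown sits at that same limit (the limit of > 63000 nM in this assay, at which 3 of the 3 values shown sit). The steps a step that the two limits leave unreadable from compound 1 to compound 3 and a step that the two limits leave unreadable from compound 2 to compound 3, which exchange the group on the sulfonyl sulfur, cannot be read for size, and neither can a step that the two limits leave unreadable from compound 1 to compound 2. Compound 4, `COc1ccc(Cl)cc1S(=O)(=O)Nc1ccc2oc(-c3ccccc3)nc2c1`, differs from compound 3 by 5-chloro-2-methoxyphenyl in place of 4-methoxyphenyl on a sulfonyl sulfur. With no readable step to lean on, compound 4 is expected to stay at the limit as well. The expected step that the limit leaves unreadable from compound 3 to compound 4 in this assay is thus set at no change beyond the scatter. Compound 4 is estimated at 90000 nM, with a range from 25000 nM to 400000 nM.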

Compound 4, half-maximal inhibitory concentration: > 63000 nM
Compound 4 was reported as a limit; the forecaster's own chance of this, stated with the estimate: 85%; the middle value lies beyond the limit too.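

The steps linking compound 4 with compound 1, compound 2 and compound 3 cannot be read for size, as all four compounds stand at a single limit: the limit of > 63000 nM in this assay, at which 4 of the 4 values shown sit.

The compounds shown leave open how strongly any of them inhibits, and whether the groups on the sulfonyl sulfur differ at all in this assay.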